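Pyrazole urea series: adding a second trifluoromethyl group

A few compounds are considered here, and "the series" means these few. Any claim that something is new, unique, unknown or untested is made for them only; others in the source may bear on it.

Measured compounds in a functional assay on SF-295 cells (Homo sapiens) for inhibition, read by sulforhodamine B assay, with a stated time of 48 h; on this read-out lower numbers stand for stronger inhibition of growth and higher numbers for weaker inhibition of growth:
compound 1 `COc1cc(-c2nn(-c3cccc(NC(=O)c4ccc(Cl)c(C(F)(F)F)c4)c3)cc2-c2ccncc2)ccc1Cl` gives 17300 nM
compound 2 `O=C(Nc1cccc(-n2cc(-c3ccncc3)c(-c3ccc(Cl)c(O)c3)n2)c1)Nc1cc(C(F)(F)F)cc(C(F)(F)F)c1` gives 1650 nM
compound 3 `COc1cc(-c2nn(-c3cccc(NC(=O)Nc4cccc(C(F)(F)F)c4)c3)cc2-c2ccncc2)ccc1Cl` gives 1130 nM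

Compound 3 stands at the lowest number of the three, though compound 2 sits within the scatter of it; only compound 1 is clearly apart, and the step of a 15-fold lower number from compound 1 to compound 3 (1.18 log units; beyond the scatter) is the one large move in the set. That step concerns the amide-to-urea change and the replacement of the 4-chloro-3-(trifluoromethyl)phenyl group, so it does not speak directly to the present question.

Compound 4 `COc1cc(-c2nn(-c3cccc(NC(=O)Nc4cc(C(F)(F)F)cc(C(F)(F)F)c4)c3)cc2-c2ccncc2)ccc1Cl` differs from compound 3 by trifluoromethyl in place of hydrogen on an aromatic carbon. Among the compounds with values here, the only measured compound carrying the same bis(trifluoromethyl)phenyl urea is compound 2, whose core differs from compound 3 in a second place, so no single step covers the change; the values of compound 2 and compound 3 lie within the scatter of each other, which is all that pair shows.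

Nothing here points to a shift beyond the scatter. In this assay compound 4 is expected to sit near compound 3, with an expected step of a 1.2-fold higher number from compound 3 to compound 4 (0.06 log units; within the scatter). The estimate for compound 4 is 1300 nM, expected to fall between 500 nM and 3500 nM.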

Compound 4, concentration for total growth inhibition: 1230 nM
Beside the measured number, compound 4's estimate is 1.1-fold (0.02 log units) above it; the range from low to high includes it.
By their numbers in this assay, from the lowest: compounds 3, 4 and 2 (each within the scatter of the next); then compound 1.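

In this assay, adding trifluoromethyl in place of hydrogen on an aromatic carbon, meta to a trifluoromethyl group, gives a 1.1-fold higher number from compound 3 to compound 4 (0.04 log units; within the scatter), so a second trifluoromethyl group at this position is accepted without a shift this read-out can resolve. With the bis(trifluoromethyl)phenyl urea held fixed, methyl in place of hydrogen on the oxygen gives a 1.3-fold lower number from compound 2 to compound 4 (0.13 log units; within the scatter), which separates the change on the core from the urea change that compound 2 and compound 3 could not isolate, and it too leaves the number within the scatter. No measured evidence explains why either change leaves the number in place.

The compounds shown leave open whether an amine or a carboxylic acid on this aromatic carbon would move the number beyond the scatter. They also leave open whether the added trifluoromethyl group behaves alike on a core other than that of compound 3.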